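This account rests on a few compounds, and the source may have more. Where it says the series, first, only, none or still open, it means among the compounds named here.

Measured in an ADME assay on microsomes from liver (Rattus norvegicus), read by LC-MS, using NADPH, with a stated time of 10 min, tested at 0.5 uM; a higher number here means that more of the compound is left, a lower number that less of the compound is left:
- Compound 1 `Cc1ccc(-c2cc3nc(C)c(C(OC(C)(C)C)C(=O)O)c(-c4cc(F)c5c(c4C)CCCO5)n3n2)cc1`: 94%
- Compound 2 `Cc1nc2cc(-c3cccc(Oc4ccccc4)c3)nn2c(-c2cc(F)c3c(c2C)CCCO3)c1C(OC(C)(C)C)C(=O)O`: 97%
- Compound 3 `Cc1nc2cc(-c3cccc(-c4ccccc4)c3)nn2c(-c2cc(F)c3c(c2C)CCCO3)c1[C@H](OC(C)(C)C)C(=O)O`: 96%

These three values lie within the scatter of one another, so compound 3 at 96% is not separated from either neighbour. Compound 4 `Cc1nc2cc(-c3cccc(-c4ccccc4)c3)nn2c(-c2cc(F)c3c(c2C)CCCO3)c1C(OC(C)(C)C)C(=O)O` is the next to be read. Its structure differs from compound 3 as follows: the two compounds have the same atoms and bonds; at least one stereo element is drawn with a configuration in one of them and without one in the other: 1 of 1 stereo elements differ; a stereocentre at a saturated chain carbon is drawn S in compound 3 and without a configuration in compound 4. The stereocentre at a saturated chain carbon is drawn S in compound 3 and without a configuration in compound 4. Compound 2, also drawn without a configuration there, gives 97%. No step beyond the scatter is expected in this assay, in either direction. The expected step is small: a number 1 percentage points lower from compound 3 to compound 4 (within the scatter). The estimate for compound 4 is 95%, with an expected range of 88% to 100%.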

Compound 4, percent of the compound remaining: 100%
Compound 4: middle estimate off by 5 percentage points, on the low side, and the stated range covers the measured number.
By their numbers in this assay, from the lowest: compounds 1, 3, 2 and 4 (each within the scatter of the next).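

In this assay, the drawn configuration at the saturated chain carbon has no effect that can be separated from the scatter, with a number 4 percentage points higher from compound 3 to compound 4 (within the scatter). The aromatic substituent gives the same picture: phenyl in place of phenoxy gives a number 3 percentage points higher from compound 2 to compound 4 (within the scatter), and 3-phenylphenyl in place of 4-methylphenyl gives a number 6 percentage points higher from compound 1 to compound 4 (within the scatter). The only structural difference behind the first step is this: the fact that one of compounds 3 and 4 is drawn with a defined configuration and the other without, at the place where they differ

As far as these compounds go, the composition of compound 4 at the undefined stereocentre remains open. Also open, from the compounds shown here alone, is whether an amide in place of the carboxylic acid, or an amine on the outer phenyl, would separate from these values.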